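The source may hold more compounds than are shown below. What is called first, only, known or untested is meant among the compounds shown, and "the series" means these compounds.

Compound 1 `COc1ccc(/C=C2\S/C(=N\c3csc(-c4ccc(Cl)cc4)c3)NC2=O)cc1` gives 28100 nM in a functional assay on SW-620 cells (Homo sapiens) for cytotoxicity, read by MTT assay, with a stated time of 72 h; on this read-out lower numbers stand for stronger inhibition and higher numbers for weaker inhibition. Compound 2 `CN(C)c1ccc(/C=C2\S/C(=N\c3csc(-c4ccc(Cl)cc4)c3)NC2=O)cc1` gives 800 nM. Compound 3 `COc1ccc(/C=C2\S/C(=N\c3csc(-c4ccc(Cl)cc4)c3)NC2=O)cc1OC` sits at the limit of > 50000 nM in this assay, at which 1 of the 3 values shown sits, so for it only a limit, > 50000 nM, and no number is known.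

Compound 4 `O=C1N/C(=N/c2csc(-c3ccc(Cl)cc3)c2)S/C1=C\c1ccc(F)cc1` differs from compound 3 by 4-fluorophenyl in place of 3,4-dimethoxyphenyl on a double-bonded chain carbon bound to a double-bonded ring carbon. The measured steps touching this ring are an at least 1.7-fold higher number from compound 1 to compound 3 (0.25 log units; that floor lies within the scatter), which lies within the scatter, and an at least 62-fold higher number from compound 2 to compound 3 (1.79 log units; beyond the scatter), which is large. Going by the values given here, neither swaps a methoxy-bearing ring for a fluorophenyl, so the fluorine has no precedent here; removing both methoxy groups, however, points back toward the level of compound 1. A step of an at least 2.2-fold lower number from compound 3 to compound 4 (0.35 log units; beyond the scatter) toward a lower number is therefore expected. The estimate for compound 4 is 22000 nM, expected between 5000 nM and 60000 nM.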

Compound 4, half-maximal inhibitory concentration: 8700 nM
Compound 4: the middle estimate sits 2.5-fold (0.40 log units) above what was measured; the range from low to high includes it.
By their numbers in this assay, from the lowest: compound 2; then compound 4; then compound 1. At a limit, above all of these: compound 3.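

Fluoro on this aromatic carbon sits at an intermediate level, giving a lower number than methoxy, with a 3.2-fold lower number from compound 1 to compound 4 (0.51 log units; beyond the scatter), but a higher number than dimethylamino, with an 11-fold higher number from compound 2 to compound 4 (1.04 log units; beyond the scatter). Replacing 3,4-dimethoxyphenyl with 4-fluorophenyl gives an at least 5.7-fold lower number from compound 3 to compound 4 (0.75 log units; beyond the scatter), and this step is only a floor. Compound 3 stands at a limit and not at a number: the limit of > 50000 nM in this assay, at which 1 of the 4 values shown sits.

The compounds shown leave open whether chloro or bromo would match fluoro here. They also leave open whether a primary amine or pyrrolidine would reach the level of compound 2.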